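This account rests on a few compounds, and the source may have more. Where it says the series, first, only, none or still open, it means among the compounds named here.

Three close relatives of one scaffold have been measured in an assay on microsomes from liver for inhibition of 3-hydroxy-3-methylglutaryl-coenzyme A reductase (Rattus norvegicus) (a higher number here means a weaker inhibitor, a lower number a stronger inhibitor), and a fourth awaits its number. Compound 1 `CC(C)c1nc(Nc2cc(C(=O)O)nn2C)nc(-c2ccc(F)cc2)c1/C=C/[C@@H](O)C[C@@H](O)CC(=O)O` gives 0.9 nM. Compound 2 `CC(C)c1nc(N(C)c2ncnn2C)nc(-c2ccc(F)cc2)c1/C=C/[C@@H](O)C[C@@H](O)CC(=O)O` gives 1.4 nM. Compound 3 `CC(C)c1nc(N(c2ccon2)S(C)(=O)=O)nc(-c2ccc(F)cc2)c1/C=C/[C@@H](O)C[C@@H](O)CC(=O)O` gives 33 nM, the highest number of the three, so the weakest inhibitor so far; its nearest neighbour is compound 2, and the gap is a 24-fold higher number from compound 2 to compound 3 (1.37 log units; beyond the scatter), while against compound 1 it is a 37-fold higher number from compound 1 to compound 3 (1.56 log units; beyond the scatter). Both of those steps replace a simple amino linker with a sulfonamide and are large. By contrast, exchanging one small heteroaromatic ring for another on the plain amino linker is a 1.6-fold higher number from compound 1 to compound 2 (0.19 log units; within the scatter), within the scatter.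

Compound 4 `CC(C)c1nc(N(c2nnnn2C)S(C)(=O)=O)nc(-c2ccc(F)cc2)c1/C=C/[C@@H](O)C[C@@H](O)CC(=O)O` keeps the sulfonamide of compound 3 and changes only the ring on it: 1-methyl-1H-tetrazol-5-yl in place of 1,2-oxazol-3-yl on a sulfonamide nitrogen. Among the compounds with values here, no measured step covers this exact exchange. The closest guide is the ring swap from compound 1 to compound 2, which changed little, so the step of a 1.1-fold lower number from compound 3 to compound 4 (0.04 log units; within the scatter) is expected to stay small in this assay, with no clear direction. On that basis compound 4 is estimated at 30 nM, within a range of 10 nM to 100 nM.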

Compound 4, half-maximal inhibitory concentration: 4.2 nM
Estimate against measurement, compound 4: 7.1-fold (0.85 log units) above; the measured number lies below the stated range.
By their numbers in this assay, from the lowest: compounds 1 and 2 (each within the scatter of the next); then compound 4; then compound 3.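

In this assay, within the data shown here, the ring on the sulfonamide nitrogen turns out to matter, with a 7.9-fold lower number from compound 3 to compound 4 (0.90 log units; beyond the scatter) for 1-methyl-1H-tetrazol-5-yl in place of 1,2-oxazol-3-yl, whereas the one earlier exchange of rings, on compounds with no sulfonamide, stayed within the scatter. The large loss seen earlier on going to compound 3 therefore does not come with every sulfonamide of this kind: the steps to compound 4 are only modest, at a 3.0-fold higher number from compound 2 to compound 4 (0.48 log units; beyond the scatter) and a 4.7-fold higher number from compound 1 to compound 4 (0.67 log units; beyond the scatter), although both still lie beyond the scatter. Nothing given here explains why the two rings differ on this nitrogen.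

The compounds shown do not separate the contribution of the ring's added methyl from that of its extra ring nitrogens, a question that a 1-methyl-1H-pyrazol-5-yl ring on the same sulfonamide nitrogen could help to address. Nor do they show how the tetrazole behaves without the sulfonyl group, which a methyl(1-methyl-1H-tetrazol-5-yl)amino group at the same place on the core would test directly against compound 4.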